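Replacing the Pyridyl Substituent of Compound 2

The compounds below may be only part of what the source reports. "The series", "measured", "known", "first", "only" and "open" are said of these compounds alone.

Of the compounds shown here, two have been measured so far. Compound 1 `Cc1c(-c2cc(Cl)cc(Cl)c2)c(C(=O)O)nn1-c1nc(-c2cc(Cl)cc(Cl)c2)c(SC(C)C)s1` and compound 2 `CCOc1ncccc1-c1c(C)nn(-c2nc(-c3ccc(Cl)c(Cl)c3)c(SC(C)C)s2)c1C(=O)O` were both tested in a functional assay on BJAB cells (Homo sapiens) for antiproliferative activity, with a stated time of 4 days; on this read-out lower numbers stand for an effect already at smaller amounts and higher numbers for an effect only at larger amounts of compound. In this assay compound 1 gives 2000 nM. In this assay, among the compounds with values here, compound 2 gives 11000 nM, the highest of the two numbers; its only neighbour, compound 1, stands at a lower number by a margin beyond the usual scatter. Compound 3 `CNc1cc(-c2c(C)nn(-c3nc(-c4ccc(Cl)c(Cl)c4)c(SC(C)C)s3)c2C(=O)O)ccn1` has not yet been measured. It differs from compound 2 in one place: 2-(methylamino)pyridin-4-yl in place of 2-ethoxypyridin-3-yl on an aromatic carbon. Within the data shown here, no measured pair isolates such a change, so the size of the step cannot be read from the data. One expects a modest step in this assay from compound 2 toward a lower number, possibly no more than the scatter, estimated as a 1.8-fold lower number from compound 2 to compound 3 (0.26 log units; within the scatter). Compound 3 is accordingly estimated at 6000 nM, within a range from 2000 nM to 18000 nM.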

Compound 3, half-maximal effective concentration: 18000 nM
Beside the measured number, compound 3's estimate is 3.0-fold (0.48 log units) below it; the measured number falls inside the stated range.
By their numbers in this assay, from the lowest: compound 1; then compounds 2 and 3 (each within the scatter of the next).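

In this assay, putting 2-(methylamino)pyridin-4-yl in place of 2-ethoxypyridin-3-yl, on the aromatic carbon next to the ring atom that bears a carboxy group, gives a 1.6-fold higher number from compound 2 to compound 3 (0.21 log units; within the scatter) and so leaves compound 2 and compound 3 within the scatter of each other. This read-out therefore does not separate the two pyridyl substituents, even though they differ in where the ring is attached, in the chain they carry and in the hydrogen-bond donor found only in the entering group. No supporting measurement bears on this result.

Going by these compounds, whether a pyridyl group carrying a primary amine or a longer alkoxy chain such as propoxy would move the number beyond the scatter stays open. Also open, on these data alone, is whether an amide in place of the carboxy group would change what this position tolerates.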